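The compounds below may be only part of what the source reports. "The series", "measured", "known", "first", "only" and "open" are said of these compounds alone.

Measured compounds:
compound 1 `O=C(O)c1ccc2nc(CN3CCC[C@H](O[C@H](CO)c4cc(Cl)cc(Cl)c4)[C@@H]3c3ccccc3)[nH]c2c1`: 43000 nM
compound 2 `Cc1cc(C(=O)O)ccc1CN1CCC[C@H](O[C@H](CO)c2cc(Cl)cc(Cl)c2)[C@@H]1c1ccc(F)cc1`: "nd" (no result reported)

Notes on the series. In an assay on isolated protein for activation of cGMP-dependent protein kinase 1 (Homo sapiens), read by ADP-Glo, with stated times of 30 min and 2 h (a lower number here means that less compound is needed, a higher number that more compound is needed for the effect), compound 1 gives 43000 nM. For the measured compounds named here, this is the only number in the set, so compound 1 stands alone: compound 2 has no reported result, and no comparison between two measured compounds can be drawn. On what is shown, compound 1 is a weak activator.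

Compound 3 `O=C(O)c1ccc(CN2CCC[C@H](O[C@H](CO)c3cc(Cl)cc(Cl)c3)[C@@H]2c2ccccc2)c([N+](=O)[O-])c1` is not yet measured in this assay. It differs from compound 1 by a group of 12 heavy atoms (7 carbon, 1 nitrogen, 4 oxygen; one six-membered aromatic ring of carbon only) in place of a group of 12 heavy atoms (8 carbon, 2 nitrogen, 2 oxygen; one five-membered aromatic ring with 2 hetero atoms, one six-membered aromatic ring of carbon only), on a saturated chain carbon bound to an amine nitrogen in a ring. The group that leaves carries the five-membered aromatic ring with two hetero atoms; the group that enters, 4-carboxy-2-nitrophenyl, keeps one six-membered aromatic ring of carbon only and one hydrogen-bond donor.

Going by the values given here, no measured step exists to show how this assay answers a change at this place. With only compound 1 as an anchor, the expectation is a step from compound 1 to compound 3 of a 1.1-fold lower number from compound 1 to compound 3 (0.03 log units; within the scatter), that is, none beyond the usual scatter, with a wide range to either side. Compound 3 is therefore estimated at 40000 nM, expected to fall between 10000 nM and 160000 nM.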

Compound 3, half-maximal effective concentration: 13000 nM
Estimate against measurement, compound 3: 3.1-fold (0.49 log units) above; low and high end bracket the measured number.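

For the compounds shown here, at the saturated chain carbon bound to an amine nitrogen in a ring, exchanging the group with the five-membered aromatic ring with 2 hetero atoms for 4-carboxy-2-nitrophenyl gives in this assay a 3.3-fold lower number from compound 1 to compound 3 (0.52 log units; beyond the scatter) as the first measured step at this place, modest in size. The five-membered aromatic ring with 2 hetero atoms is therefore not required for a measurable result, since one six-membered aromatic ring of carbon only, as in compound 3, gives a lower number, and this assay does respond to a change at this place. Nothing at hand bears on what lies behind this step.

The step exchanges the whole group, so the share of the nitro group cannot be separated from that of the change of ring system; a plain 4-carboxyphenyl group, or the same ring with a nitrile or an amine in place of the nitro group, would separate them. Going by these compounds, it also remains open whether the carboxylic acid is needed at all, a question that a primary amide or a tetrazole in its place would address.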